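Two Halogenated Aryl Groups on a Shared Core

A few compounds are considered here, and "the series" means these few. Any claim that something is new, unique, unknown or untested is made for them only; others in the source may bear on it.

Compound 1 `CN1CCN(CCCOc2cccc3nc(Nc4ccc(Cl)c(C(F)(F)F)c4)ccc23)CC1`: 1720 nM
Compound 2 `CN1CCN(CCCOc2cccc3nc(Nc4ccc(F)c(F)c4)ccc23)CC1`: 2370 nM

In a functional assay on NCI-H460 cells (Homo sapiens) for inhibition, read by sulforhodamine B assay, with a stated time of 48 h (on this read-out lower numbers stand for stronger inhibition of growth and higher numbers for weaker inhibition of growth), compound 2 gives 2370 nM, and compound 1 gives 1720 nM; the step of a 1.4-fold higher number from compound 1 to compound 2 (0.14 log units; within the scatter) keeps the two within the scatter of each other. Compound 3 `CN1CCN(CCCOc2cccc3nc(Nc4cc(Cl)cc(Cl)c4)ccc23)CC1` differs from compound 2 by 3,5-dichlorophenyl in place of 3,4-difluorophenyl on a nitrogen on an aromatic ring. Within the data shown here, the one measured step, a 1.4-fold higher number from compound 1 to compound 2 (0.14 log units; within the scatter), likewise exchanged one halogenated phenyl for another and produced no change beyond the scatter, so no step beyond the scatter is expected here either, a 1.2-fold lower number from compound 2 to compound 3 (0.07 log units; within the scatter). Compound 3 is therefore estimated at 2000 nM, ranging from 800 nM to 5000 nM.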

Compound 3, concentration for 50% growth inhibition: 1840 nM
The estimate for compound 3 lay 1.1-fold (0.04 log units) above the measured number; the range from low to high includes it.
By their numbers in this assay, from the lowest: compounds 1, 3 and 2 (each within the scatter of the next).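

In this assay, both a 1.3-fold lower number from compound 2 to compound 3 (0.11 log units; within the scatter) and a 1.1-fold higher number from compound 1 to compound 3 (0.03 log units; within the scatter) show that the third halogenated phenyl also brings no change beyond the scatter. On a nitrogen on an aromatic ring, 3,5-dichlorophenyl therefore does not separate from 3,4-difluorophenyl or 4-chloro-3-(trifluoromethyl)phenyl, even though its two chlorine atoms sit differently on the ring. No evidence on the reason for this accompanies the result. From the compounds shown here alone, it remains open whether an unsubstituted phenyl, or a phenyl bearing a methoxy group, a nitrile or a carboxylic acid, would stay within the same scatter.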